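Paw edema series: methyl to methoxy on the pyridine-type ring

The compounds below may be only part of what the source reports. "The series", "measured", "known", "first", "only" and "open" are said of these compounds alone.

Measured in a functional assay on the whole organism (strain Sprague-Dawley) for inhibition, with Rattus norvegicus as the target, read by paw edema, with a stated time of 180 min, at a dose of 10 mg/kg by the oral route; a lower number here means a weaker effect, a higher number a stronger effect of the compound at the dose given:
compound 1 `COc1ccnc(CNc2ccc3c(c2)nc(C)n3C[C@@H](O)[C@H]2O[C@H](O)[C@@H](O)[C@H]2O)c1OC` gives 41%
compound 2 `COc1ccnc(CNc2ccc3[nH]c(C)nc3c2)c1C` gives 11%

Among the measured compounds shown here, compound 2 stands lowest of the two numbers; its nearest neighbour, compound 1, lies higher by a gap beyond the scatter, though the two structures differ in more than one place, so no single step is known. Compound 3 `COc1ccnc(CNc2ccc3[nH]c(C)nc3c2)c1OC` differs from compound 2 by methoxy in place of methyl on an aromatic carbon. For the measured compounds named here, with no step of this kind measured, the expected change from compound 2 to compound 3 is a small rise, a number 9 percentage points higher from compound 2 to compound 3 (within the scatter), possibly not beyond the scatter. Compound 3 is estimated at 20%, range 5% to 38%.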

Compound 3, a percentage reported as inhibition, in the whole organism at one dose (the size of the read-out at that dose, not a potency): 15%
Compound 3: the middle estimate sits 5 percentage points above what was measured; measured number inside the range.
By their numbers in this assay, from the lowest: compounds 2 and 3 (each within the scatter of the next); then compound 1.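

In this assay, methoxy in place of methyl on this aromatic carbon gives a number 4 percentage points higher from compound 2 to compound 3 (within the scatter), so this swap does not separate the two compounds. A hydrogen atom in place of the group of 11 heavy atoms on the aromatic nitrogen gives a number 26 percentage points lower from compound 1 to compound 3 (beyond the scatter), which ties a gap beyond the scatter to that nitrogen, something the earlier pair, differing in more than one place, could not show. Nothing available explains either step.

Open, from the compounds shown here alone, is whether an amine or a carboxylic acid on this aromatic carbon would move the read-out. Also open, going by these compounds, is how much of the group on the nitrogen is needed, for instance whether a simple hydroxyethyl chain would do.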